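Chalcone-linked pyrazolopyrimidines: swapping the aryl ketone substituent

A few compounds are considered here, and "the series" means these few. Any claim that something is new, unique, unknown or untested is made for them only; others in the source may bear on it.

Measured compounds in a functional assay on A549 cells (Homo sapiens) for antiproliferative activity, read by MTT assay, with a stated time of 24 h; a lower number here means a stronger inhibitor, a higher number a weaker inhibitor:
compound 1 `COc1ccc(-c2cc(/C=C/C(=O)c3cc(OC)c(OC)c(OC)c3)nc3cc(-c4ccccc4)nn23)cc1OC` gives 7200 nM
compound 2 `COc1ccc(C(=O)/C=C/c2cc(-c3cc(OC)c(OC)c(OC)c3)n3nc(-c4ccccc4)cc3n2)cc1OC` gives 17800 nM
compound 3 `COc1ccc(-c2cc(/C=C/C(=O)c3ccc(OC)c(OC)c3)nc3cc(-c4ccccc4)nn23)cc1` gives 7400 nM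

Compound 1 shows the lowest number of the three, although compound 3 sits within the scatter of it, so no order between these two can be claimed; compound 2 lies beyond the scatter from both. Compound 1 and compound 3 differ in more than one place, so their values can only be set side by side.

Compound 4 `COc1ccc(-c2cc(/C=C/C(=O)c3ccc(Cl)cc3)nc3cc(-c4ccccc4)nn23)cc1OC` has not yet been measured. It differs from compound 1 as follows: 4-chlorophenyl in place of 3,4,5-trimethoxyphenyl on a carbonyl carbon.

Among the measured compounds shown here, the only measured step that touches a trimethoxyphenyl group is a 2.4-fold lower number from compound 2 to compound 3 (0.38 log units; beyond the scatter), but there the replacement sits on an aromatic carbon and brings in a 4-methoxyphenyl rather than a 4-chlorophenyl, so it bears on the present change only loosely. Nothing measured here shows a chlorine-bearing aryl on the carbonyl carbon. Compound 4 is therefore expected to show a modest step at most, a 1.2-fold lower number from compound 1 to compound 4 (0.08 log units; within the scatter), with wide uncertainty. The estimate for compound 4 in this assay is 6000 nM, within 2500 nM to 15000 nM.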

Compound 4, half-maximal inhibitory concentration: 15400 nM
Compound 4: the middle estimate sits 2.6-fold (0.41 log units) below what was measured; the measured number lies above the stated range.
By their numbers in this assay, from the lowest: compounds 1 and 3 (each within the scatter of the next); then compounds 4 and 2 (each within the scatter of the next).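

In this assay, the change at the carbonyl carbon gives a 2.1-fold higher number from compound 1 to compound 4 (0.33 log units; beyond the scatter), the first step measured at this position with the rest of compound 1 held fixed. It shows that the aryl group on the carbonyl carbon is not interchangeable here: 4-chlorophenyl does not match 3,4,5-trimethoxyphenyl, although the step is modest. Because the swap removes the methoxy groups and brings in chlorine at once, this single pair cannot separate the two, and nothing measured here accounts for the step.

As far as these compounds go, it remains open how an unsubstituted phenyl, a single methoxy-bearing phenyl or a dimethylamino-bearing phenyl would read on this carbonyl carbon with the rest of compound 1 unchanged. Whether the same swap gives a similar step on the other aryl pattern seen in compound 3 also stays unsettled.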